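Swapping a Morpholine Ring for a Piperidine Ring

The source may hold more compounds than are shown below. What is called first, only, known or untested is meant among the compounds shown, and "the series" means these compounds.

Of the compounds shown here, three have been tested in a functional assay on SW480 cells (Homo sapiens) for antiproliferative activity, read by MTT assay, with a stated time of 72 h; on this read-out lower numbers stand for stronger inhibition and higher numbers for weaker inhibition. Compound 1 `COc1ccc2occ(CSC(=S)N3CCOCC3)c(=O)c2c1` gives 7100 nM, compound 2 `O=c1c(CSC(=S)N2CCCCC2)coc2cc(Cl)ccc12` gives 790 nM, and compound 3 `O=c1c(CSC(=S)N2CCOCC2)coc2ccccc12` gives 5900 nM. Compound 3 thus holds the second highest of the three numbers, close to compound 1 and far from compound 2. Among the measured compounds shown here, the only single-point step measured so far, a 1.2-fold lower number from compound 1 to compound 3 (0.08 log units; within the scatter), concerns a different position and says nothing about the change ahead. Compound 4 `O=c1c(CSC(=S)N2CCCCC2)coc2ccccc12` differs from compound 3 by piperidin-1-yl in place of morpholin-4-yl on a thiocarbonyl carbon. Compound 2 also carries a piperidin-1-yl group, yet it differs from compound 3 in a second place as well, so its lower number is only a hint. Compound 4 is therefore expected to give a moderately lower number, a 2.4-fold lower number from compound 3 to compound 4 (0.37 log units; beyond the scatter), with an estimate of 2500 nM and a range from 800 nM to 7000 nM.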

Compound 4, half-maximal inhibitory concentration: 1200 nM
Estimate against measurement, compound 4: 2.1-fold (0.32 log units) above, and the stated range covers the measured number.
By their numbers in this assay, from the lowest: compounds 2 and 4 (each within the scatter of the next); then compounds 3 and 1 (each within the scatter of the next).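

In this assay the group on the thiocarbonyl carbon clearly matters, since piperidin-1-yl in place of morpholin-4-yl gives a 4.9-fold lower number from compound 3 to compound 4 (0.69 log units; beyond the scatter) with the rest of the molecule unchanged. Hydrogen in place of chloro gives a 1.5-fold higher number from compound 2 to compound 4 (0.18 log units; within the scatter) and so shows no change that stands out from the scatter. Nothing measured here explains why the ring swap has this effect. Still open, from the compounds shown here alone, is whether the smaller pyrrolidin-1-yl ring, the open-chain diethylamino group or a piperazin-1-yl ring would give numbers like that of compound 4.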